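Same Change on a Second Core: Estimating Compound 4

The source may report more compounds than this note shows. Statements on the series, on what has been measured and on what is new or still open speak of the compounds shown alone.

Of the compounds shown here, three sharing one core have been measured. Compound 1 `COC(=O)/C=C/c1cccc(N(Cc2ccc(/C=C/c3ccc(F)cc3)cc2)C(=O)C(C)C)c1`, compound 3 `COC(=O)/C=C/c1cccc(N(Cc2ccc(/C=C/c3cccc(Cl)c3)cc2)C(=O)C(C)C)c1` and compound 2 `COC(=O)/C=C/c1cccc(N(Cc2ccc(/C=C/c3cccc(Cl)c3)cc2)C(=O)C2CCCCC2)c1` were tested in an assay on isolated protein with Bile acid receptor (Homo sapiens) as the target; a lower number here means that less compound is needed, a higher number that more compound is needed for the effect. Compound 1 gives 120 nM, compound 3 gives 164 nM and compound 2 gives 165 nM. The change 4-fluorophenyl in place of 3-chlorophenyl on a double-bonded chain carbon bound to a double-bonded chain carbon made a step of a 1.4-fold lower number from compound 3 to compound 1 (0.14 log units; within the scatter). The cores of compound 3 and compound 2 differ by cyclohexyl in place of isopropyl on a carbonyl carbon, a step of a 1.0-fold lower number from compound 2 to compound 3 (0.00 log units; within the scatter). Compound 4 `COC(=O)/C=C/c1cccc(N(Cc2ccc(/C=C/c3ccc(F)cc3)cc2)C(=O)C2CCCCC2)c1` has not yet been measured in this assay. It carries the same change, (4-fluorophenyl in place of 3-chlorophenyl on a double-bonded chain carbon bound to a double-bonded chain carbon), made on compound 2 at the same place. Beside the earlier step, compound 4 is expected to give 120 nM, a step of a 1.4-fold lower number from compound 2 to compound 4 (0.14 log units; within the scatter), because compound 2 gives 165 nM and the same change from compound 3 to compound 1 gave a 1.4-fold lower number from compound 3 to compound 1 (0.14 log units; within the scatter). The range for compound 4 is estimated to run from 60 nM to 250 nM.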

Compound 4, half-maximal effective concentration: 185 nM
Estimate against measurement, compound 4: 1.5-fold (0.19 log units) below, and the stated range covers the measured number.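

In this assay, 4-fluorophenyl in place of 3-chlorophenyl gives a 1.1-fold higher number from compound 2 to compound 4 (0.05 log units; within the scatter), and the gap to the same change on the other core is small: the same change on two cores in this assay, a 1.4-fold lower number (0.14 log units; within the scatter) from compound 3 to compound 1 and a 1.1-fold higher number (0.05 log units; within the scatter) from compound 2 to compound 4, 1.5-fold (0.19 log units) apart, within the scatter of two such steps. Cyclohexyl in place of isopropyl gives a 1.5-fold higher number from compound 1 to compound 4 (0.19 log units; within the scatter), and the comparison with its earlier step reads the same way: the same change on two cores in this assay, a 1.0-fold lower number (0.00 log units; within the scatter) from compound 2 to compound 3 and a 1.5-fold lower number (0.19 log units; within the scatter) from compound 4 to compound 1, 1.5-fold (0.19 log units) apart, within the scatter of two such steps. Within the data shown here, both changes therefore behave alike on the two cores, but every step here lies within the scatter, so this shows only that neither change has a measurable effect on these compounds, not that a larger effect would carry from one core to another.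

On these data alone, it remains open whether a step beyond the scatter would carry over in the same way. A carboxylic acid or an amine in place of the 4-fluorophenyl could test this.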